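A few compounds are considered here, and "the series" means these few. Any claim that something is new, unique, unknown or untested is made for them only; others in the source may bear on it.

Working notes on the series. Among the measured compounds shown here, in a functional assay on TK-10 cells (Homo sapiens) for inhibition, read by sulforhodamine B assay, with a stated time of 48 h (on this read-out lower numbers stand for stronger inhibition of growth and higher numbers for weaker inhibition of growth), compound 1 `Cc1ccc(NC(=O)/C=C/c2ccccc2)c(C(N)=O)c1` gives 25800 nM and compound 2 `NC(=O)c1cc(Br)ccc1NC(=O)/C=C/c1ccccc1` gives 2670 nM, the lower of the two numbers so far. The next change leads to compound 3 `NC(=O)c1cc(I)ccc1NC(=O)/C=C/c1ccccc1`, with iodo in place of bromo on an aromatic carbon, meta to a carbamoyl group and para to a large group (iodo in place of bromo on an aromatic carbon). For the measured compounds named here, only one measured step bears on this: a 9.7-fold lower number from compound 1 to compound 2 (0.99 log units; beyond the scatter), which came with bromo in place of methyl. That single step replaced a methyl, not one halogen with another, so it gives only a loose guide. In this assay a smaller step is therefore expected, leaning to a lower number and most likely not beyond the scatter. The expected change is a 1.3-fold lower number from compound 2 to compound 3 (0.13 log units; within the scatter). Compound 3 is estimated at 2000 nM, with an expected range of 700 nM to 6000 nM.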

Compound 3, concentration for 50% growth inhibition: 3150 nM
Compound 3: the middle estimate sits 1.6-fold (0.20 log units) below what was measured; the range from low to high includes it.
By their numbers in this assay, from the lowest: compounds 2 and 3 (each within the scatter of the next); then compound 1.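

In this assay, iodo in place of bromo at this position, meta to a carbamoyl group and para to a large group, gives a 1.2-fold higher number from compound 2 to compound 3 (0.07 log units; within the scatter), so compound 2 and compound 3 cannot be separated and the two halogens show no order here. Iodo in place of methyl gives an 8.2-fold lower number from compound 1 to compound 3 (0.91 log units; beyond the scatter), so the lower number relative to compound 1, until now seen only with bromo in a 9.7-fold lower number from compound 1 to compound 2 (0.99 log units; beyond the scatter), holds for a second halogen. No measured evidence on these compounds accounts for this pattern.

The compounds shown leave open how a chloro, a fluoro, a methoxy or an amine would read at this position. They also leave open whether the same reading would hold with a carboxylic acid or a nitrile in place of the carbamoyl group.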